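Acetylation of a ring hydroxy group in two related cores

A few compounds are considered here, and "the series" means these few. Any claim that something is new, unique, unknown or untested is made for them only; others in the source may bear on it.

Compound 1 `COc1cc(C2=C(c3cc(C)c(OC)c(C)c3)C(O)CC2=O)cc(OC)c1OC` is measured in an ADME assay on DU-145 cells (Homo sapiens) for cytotoxicity, read by MTT assay, with a stated time of 72 h (a lower number here means a stronger inhibitor, a higher number a weaker inhibitor), and compound 1 gives > 100 ug/mL, which is a limit of the assay and not a number. Compound 2 `COc1cc(C2=C(c3cc(C)c(OC)c(C)c3)C(OC(C)=O)CC2=O)cc(OC)c1OC` carries the change (acetyl in place of hydrogen on an oxygen on a saturated carbon). Compound 2 gives > 100 ug/mL in this assay, again a limit rather than a number. The step that the two limits leave unreadable from compound 1 to compound 2 therefore cannot be read, because both values sit at the limit of > 100 ug/mL in this assay, at which 2 of the 3 values shown sit; whether the acetyl makes the compound stronger, weaker or leaves it unchanged is not told by this pair.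

Compound 3 `COc1ccc(C2=C(c3cc(OC)c(OC)c(OC)c3)C(=O)C(O)C2)cc1Cl` belongs to a different core; how the core of compound 3 differs from the core of compound 1 is not broken down here. In this assay, among the compounds with values here, compound 3 gives 40 ug/mL, the only number among the three measured values.

Compound 4 `COc1ccc(C2=C(c3cc(OC)c(OC)c(OC)c3)C(=O)C(OC(C)=O)C2)cc1Cl` is not yet measured. Within the data shown here, it differs from compound 3 by acetyl in place of hydrogen on an oxygen on a saturated carbon, the same change as the one from compound 1 to compound 2, made at the same kind of place: an oxygen on a saturated carbon whose other neighbours are a saturated ring carbon. Among the measured compounds shown here, the only precedent for this change is unreadable, so no direction can be taken from it. The step is expected to be small, a 1.1-fold higher number from compound 3 to compound 4 (0.05 log units; within the scatter), resting on the absence of any readable shift in the pair of compound 1 and compound 2. Compound 4 is thus estimated at 45 ug/mL, with a range from 15 ug/mL to 100 ug/mL, and a fair chance that only a limit is reported.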

Compound 4, half-maximal inhibitory concentration: 64 ug/mL
Estimate against measurement, compound 4: 1.4-fold (0.15 log units) below, and the stated range covers the measured number.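

Working notes on the acetyl change: in this assay, replacing hydrogen with acetyl on the oxygen of the core of compound 3 gives a 1.6-fold higher number from compound 3 to compound 4 (0.20 log units; within the scatter), so hydroxy to acetoxy on this core cannot be told apart from repeat measurement. The same change on the core of compound 1 gives no readable step, because compound 1 and compound 2 each carry a limit of the assay and not a number: the limit of > 100 ug/mL in this assay, at which 2 of the 4 values shown sit. The series therefore holds one readable instance of this change, which shows that the acetyl is tolerated on the core of compound 3 within the scatter but does not show that the change carries from one core to the other, since the second core offers nothing to set beside it, either in agreement or against it.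

The compounds shown leave open how other groups on the same oxygen would read on the core of compound 3, for example a longer acyl chain such as butyryl or an acyl chain ending in a carboxylic acid. Also open, from the compounds shown here alone, is whether an amine in place of the hydroxy would give a step beyond the scatter in this assay.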